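The source may report more compounds than this note shows. Statements on the series, on what has been measured and on what is new or still open speak of the compounds shown alone.

Three compounds have been measured in a functional assay on Ehrlich cells (Mus musculus) for antiproliferative activity, read by trypan blue exclusion, with a stated time of 2 h, tested at 100 ug/mL; on this read-out lower numbers stand for a weaker effect and higher numbers for a stronger effect at the one concentration tested:

Compound 1, `N#CC1=C(N)N(c2ccc(S(N)(=O)=O)cc2)C2=C(C(=O)CCC2)C1c1ccccc1`, gives 40%.
Compound 2, `Cc1ccc(C2C(C#N)=C(N)N(c3ccc(S(N)(=O)=O)cc3)C3=C2C(=O)CCC3)cc1`, gives 100%.
Compound 3, `N#CC1=C(N)N(c2ccc(S(N)(=O)=O)cc2)C2=C(C(=O)CCC2)C1c1cccc([N+](=O)[O-])c1`, gives 71%.

All three share one core and differ only in the group carried on one saturated ring carbon. Compound 3 stands second of the three. Compound 2 lies above it, the two being separated by a number 29 percentage points lower from compound 2 to compound 3 (beyond the scatter), and compound 1 lies below it, separated by a number 31 percentage points higher from compound 1 to compound 3 (beyond the scatter).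

Compound 4, `N#CC1=C(N)N(c2ccc(S(N)(=O)=O)cc2)C2=C(C(=O)CCC2)C1c1ccc([N+](=O)[O-])cc1`, has not yet been measured. Its change from compound 3 is 4-nitrophenyl in place of 3-nitrophenyl on a saturated ring carbon. Going by the values given here, none of the measured steps moves a nitro group from one place on the aromatic ring to another. The steps seen so far, a number 60 percentage points higher from compound 1 to compound 2 (beyond the scatter) and a number 31 percentage points higher from compound 1 to compound 3 (beyond the scatter), each put a group where there was hydrogen, while a number 29 percentage points lower from compound 2 to compound 3 (beyond the scatter) swaps one group for a different one. They show that the group on this carbon matters a great deal, but they give no direction for a change that keeps the same atoms and only rearranges them. For compound 4 the expected step is therefore a number 4 percentage points higher from compound 3 to compound 4 (within the scatter), within the scatter. In this assay the estimate for compound 4 is 75%, expected to fall between 45% and 100%.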

Compound 4, a percentage reported as activity, at one concentration (the size of the read-out at that concentration, not a potency): 100%
The estimate for compound 4 lay 25 percentage points below the measured number, and the stated range covers the measured number.
By their numbers in this assay, from the lowest: compound 1; then compound 3; then compounds 2 and 4 (each within the scatter of the next).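

In this assay, the same nitro group on the same ring carbon gives a different result once it is moved: 4-nitrophenyl in place of 3-nitrophenyl gives a number 29 percentage points higher from compound 3 to compound 4 (beyond the scatter). So at this saturated ring carbon, where the substituent sits on the aromatic ring counts as well as which substituent is present, something the earlier compounds could not show, as none of them kept the atoms and only rearranged them. Relative to the unsubstituted phenyl, the 4-nitrophenyl group gives a number 60 percentage points higher from compound 1 to compound 4 (beyond the scatter), while nitro in place of methyl gives no change at the digits printed from compound 2 to compound 4 (within the scatter), so two quite different groups on the same ring place cannot be told apart at the one concentration tested, and no measurement shown here offers a reason for any of this.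

The compounds shown leave open whether 3-methylphenyl would fall short of 4-methylphenyl in the way 3-nitrophenyl falls short of 4-nitrophenyl, so the effect of position is so far seen for nitro alone. They also leave open whether an amine or a carboxylic acid in place of the nitro group, as 4-aminophenyl or 4-carboxyphenyl, would keep the read-out where compound 2 and compound 4 stand.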